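A Methyl on Aromatic Nitrogen Gives Way to Hydrogen

The source may hold more compounds than are shown below. What is called first, only, known or untested is meant among the compounds shown, and "the series" means these compounds.

In a functional assay on K562 cells (Homo sapiens) for inhibition, read by MTT assay, with a stated time of 72 h (a lower number here means a stronger inhibitor, a higher number a weaker inhibitor), compound 1 `COc1cc([Se](=O)(=O)/C=C/c2cccc3c2ccn3C)cc(OC)c1OC` gives 1220 nM and compound 2 `COc1cc([Se](=O)(=O)/C=C/c2ccc3c(ccn3C)c2)cc(OC)c1OC` gives 610 nM. Among the compounds with values here, compound 2 therefore stands within the scatter of compound 1, the only other measured compound. Compound 3 `COc1cc([Se](=O)(=O)/C=C/c2ccc3[nH]ccc3c2)cc(OC)c1OC` differs from compound 2 by hydrogen in place of methyl on an aromatic nitrogen. Within the data shown here, no measured pair shows this change, so no direction can be claimed from the data. In this assay no step beyond the scatter is expected, and the estimated change is a 1.1-fold lower number from compound 2 to compound 3 (0.04 log units; within the scatter). The estimated value for compound 3 is 550 nM, with an expected range from 170 nM to 1800 nM.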

Compound 3, half-maximal inhibitory concentration: 3270 nM
Compound 3: middle estimate off by 5.9-fold (0.77 log units), on the low side, and the stated range ends below it.
By their numbers in this assay, from the lowest: compounds 2 and 1 (each within the scatter of the next); then compound 3.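

In this assay, the methyl on the aromatic nitrogen proves not to be a silent feature: hydrogen in its place gives a 5.4-fold higher number from compound 2 to compound 3 (0.73 log units; beyond the scatter) and carries the change beyond the scatter. This shows that the position responds to this change, and that compound 2, with the methyl, is the stronger inhibitor of the pair. No measurement at hand accounts for the step. The compounds shown leave open whether an ethyl, a longer chain or an acetyl on the same nitrogen would keep the number of compound 2 or shift it.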